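Notes on volume of distribution: compound 2 to compound 3

A few compounds are considered here, and "the series" means these few. Any claim that something is new, unique, unknown or untested is made for them only; others in the source may bear on it.

Two compounds of the series have numbers in an ADME assay on the whole organism for pharmacokinetics, with Rattus norvegicus as the target, given by the intravenous route; a lower number here means that more of the compound stays in the plasma, a higher number that more of the compound sits outside the plasma. Compound 1 `CCNC(=O)Nc1nc2cc(-c3cccnc3)cc(-c3ccccn3)c2[nH]1` gives 1.1 L/kg in this assay. Compound 2 `CCNC(=O)Nc1nc2cc(-c3cccnc3)cc(-c3ncccc3F)c2[nH]1` gives 1.6 L/kg in this assay. Within the data shown here, the one step between them, a 1.5-fold higher number from compound 1 to compound 2 (0.16 log units; within the scatter), is fluoro in place of hydrogen on an aromatic carbon. Compound 2 and compound 1 therefore sit within the scatter of each other, and neither number stands apart from the other.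

Compound 3 `CCNC(=O)Nc1nc2cc(-c3cnc(C(C)(C)O)nc3)cc(-c3ncccc3F)c2[nH]1` is the next compound. It differs from compound 2 in one place: 2-(1-hydroxy-1-methylethyl)pyrimidin-5-yl in place of pyridin-3-yl on an aromatic carbon. Among the measured compounds shown here, no measured step touches this position or this kind of exchange; the only step in hand, from compound 1 to compound 2, concerns a fluoro on the other aryl group and was itself within the scatter. There is thus nothing in the measured numbers that points to a step beyond the scatter in this assay in either direction.

For compound 3 the expected number in this assay is 1.4 L/kg, with a range of 0.7 L/kg to 2.8 L/kg. The expected step is a 1.1-fold lower number from compound 2 to compound 3 (0.06 log units; within the scatter), within the scatter.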

Compound 3, volume of distribution at steady state: 2.1 L/kg
Beside the measured number, compound 3's estimate is 1.5-fold (0.18 log units) below it; the range from low to high includes it.
By their numbers in this assay, from the lowest: compounds 1, 2 and 3 (each within the scatter of the next).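

The exchange of pyridin-3-yl for 2-(1-hydroxy-1-methylethyl)pyrimidin-5-yl is the first change shown at this position, para to a fused ring and meta to the 3-fluoropyridin-2-yl group, and in this assay it amounts to a 1.3-fold higher number from compound 2 to compound 3 (0.12 log units; within the scatter). The entering group has more heavy atoms and more hydrogen-bond acceptors than the group it replaces, a second hetero atom in its ring and a hydrogen-bond donor, so in this one pair a substantial change of group at this position leaves the read-out within the scatter. No measurement in hand bears on why this exchange gives so small a step.

The ring exchange and the added 1-hydroxy-1-methylethyl group arrive together, so the compounds shown cannot separate the contribution of the pyrimidine ring from that of the side chain, and a single pair cannot show how general the result is at this position. Also open, as far as these compounds go, is whether an amine or a carboxylic acid in place of the 1-hydroxy-1-methylethyl group would give a step beyond the scatter in this read-out.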